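Amino for hydroxy on a topoisomerase inhibitor core

A few compounds are considered here, and "the series" means these few. Any claim that something is new, unique, unknown or untested is made for them only; others in the source may bear on it.

Compound 1, `COc1cc(OC)cc(-c2cc3ccccc3c(-c3cccc(O)c3)n2)c1`: 0%
Compound 2, `COc1cc(OC)cc(-c2cc3ccccc3c(-c3cccc(N)c3)n2)c1`: 0%
Compound 3, `COc1ccc(-c2cc3cc(C)ccc3c(-c3cccc(O)c3)n2)c(C)c1`: 73.4%

In an assay on isolated protein for inhibition of DNA topoisomerase 1 (Homo sapiens), with a stated time of 30 min, tested at 100 uM (on this read-out lower numbers stand for a weaker effect and higher numbers for a stronger effect at the one concentration tested), compound 3 gives the highest of the three numbers, while compound 1 and compound 2 give the same reading. The unmeasured compound 4 is `COc1ccc(-c2cc3cc(C)ccc3c(-c3cccc(N)c3)n2)c(C)c1`, and it differs from compound 3 in one place: amino in place of hydroxy on an aromatic carbon. The same change is seen between two measured compounds, where compound 2 differs from compound 1 by amino in place of hydroxy on an aromatic carbon, and there it made no change at the digits printed from compound 1 to compound 2 (within the scatter). The difference between the core of compound 1 and the core of compound 3 is not broken down here. Since compound 1 and compound 2 both sit at the bottom of the scale in this assay, their step says little about how much room the change has to move a high number. The step from compound 3 to compound 4 is therefore expected to be a modest loss, a number 15.4 percentage points lower from compound 3 to compound 4 (beyond the scatter). For compound 4 the estimated result in this assay is 58%, with a range from 20% to 85%.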

Compound 4, a percentage reported as inhibition, at one concentration (the size of the read-out at that concentration, not a potency): 79.7%
The estimate for compound 4 lay 21.7 percentage points below the measured number; measured number inside the range.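

In this assay amino in place of hydroxy gives a number 6.3 percentage points higher from compound 3 to compound 4 (within the scatter) and so leaves the reading on this core unchanged within the usual scatter. Set beside the earlier step, the change looks the same on both cores: the same change on two cores in this assay, no change at the digits printed (within the scatter) from compound 1 to compound 2 and a number 6.3 percentage points higher (within the scatter) from compound 3 to compound 4, 6.3 percentage points apart, within the scatter of two such steps. This does not show that the swap can be carried safely to any core in this series, as only two cores are shown, and compound 1 gives 0% and compound 2 gives 0% at the bottom of the scale, where a loss could not appear at all.

From the compounds shown here alone, whether a methoxy group, an acetamide or a carboxylic acid in the same place would hold the reading stays open, and so does how the hydroxy and amino compounds compare across a range of concentrations rather than at a single one. Also open, going by these compounds, is which part of the difference between the core of compound 1 and the core of compound 3 separates their readings.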